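Inverting One Stereocentre of Compound 3

A few compounds are considered here, and "the series" means these few. Any claim that something is new, unique, unknown or untested is made for them only; others in the source may bear on it.

In an ADME assay on liver for metabolic stability, with Liver microsome (Rattus norvegicus) as the target, read by LC-MS, using microsomes, with a stated time of 5 h (a lower number here means slower removal, a higher number faster removal of the compound), compound 1 (`OC(c1ncccn1)C1(c2ccc(OC(F)(F)F)cc2)CCC1`) gives 483 mL/min/kg and compound 2 (`O[C@@]1(c2ccccn2)CC[C@@H](c2ccc(C(F)(F)F)cc2)C1`) gives 2520 mL/min/kg on the same read-out of clearance. Compound 3 (`O[C@H](c1ccccn1)[C@]1(c2ccc(Cl)c(Cl)c2)CCO1`) gives 50 mL/min/kg there, the lowest of the three numbers and beyond the scatter from both of the others. Compound 4 (`O[C@H](c1ccccn1)[C@@]1(c2ccc(Cl)c(Cl)c2)CCO1`) is still unmeasured. It differs from compound 3 by the two compounds have the same atoms and bonds and differ only in configuration as drawn: 1 of 2 stereo elements differ; a stereocentre at a saturated ring carbon is drawn R in compound 3 and S in compound 4 and nothing more: the two have the same atoms and bonds, and a stereocentre at a saturated ring carbon is drawn R in compound 3 and S in compound 4. Among the compounds with values here, no pair of measured compounds shows what such a change does in this assay so the expectation is loose. Within the data shown here, the expected step, a 2.0-fold higher number from compound 3 to compound 4 (0.30 log units; within the scatter), is an estimated modest move toward faster removal, resting only on compound 3 (50 mL/min/kg) holding the lowest number so far. For compound 4 the estimated clearance is 100 mL/min/kg, with an expected range from 30 mL/min/kg to 350 mL/min/kg, and the measurement is still to come.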

Compound 4, clearance: 1000 mL/min/kg
For compound 4 the middle estimate is 10-fold (1.00 log units) below the measured one, and the stated range ends below it.
By their numbers in this assay, from the lowest: compound 3; then compound 1; then compound 4; then compound 2.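

In this assay, within the data shown here, inverting the stereocentre at a saturated ring carbon from R to S gives a 20-fold higher number from compound 3 to compound 4 (1.30 log units; beyond the scatter), the first comparison here in which only one place differs. Among these compounds, this shows that configuration at this position can by itself shift clearance by a large step, which the earlier compounds could not show, as no pair among them differed in one place. The step can be assigned to this one stereocentre because no atom or bond changes: the fact that compounds 3 and 4 differ only in the configuration as drawn.

The compounds shown leave open whether the other stereo element, which compounds 3 and 4 share, has a comparable effect, and why this inversion speeds removal. As far as these compounds go, it also remains open whether the same inversion would produce a step of similar size with an amine in place of the hydroxyl group.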